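The source may hold more compounds than are shown below. What is called first, only, known or untested is meant among the compounds shown, and "the series" means these compounds.

Within the data shown here, compound 2, `O=C(CCc1ccc(C(F)(F)F)cc1)Nc1ccc2nc(N3CCCCCC3)ccc2c1`, gives 1800 nM in a functional assay on HEK293 cells for activation of melanin-concentrating hormone receptor 1 (Rattus norvegicus), read by inositol phosphate accumulation (on this read-out lower numbers stand for an effect already at smaller amounts and higher numbers for an effect only at larger amounts of compound), the highest of the two numbers measured so far. Among the measured compounds shown here, its only measured neighbour is compound 1, `NC1CCN(c2ccc3cc(NC(=O)CCc4ccc(C(F)(F)F)cc4)ccc3n2)C1`, which in this assay gives 200 nM; the step of a 9.0-fold higher number from compound 1 to compound 2 (0.95 log units; beyond the scatter) is the one change, the azepan-1-yl in place of 3-aminopyrrolidin-1-yl on an aromatic carbon.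

Compound 3, `O=C(CCc1ccc(C(F)(F)F)cc1)Nc1ccc2nc(N3CC4CC3CO4)ccc2c1`, has not yet been measured. It differs from compound 2 by a group of 7 heavy atoms (5 carbon, 1 nitrogen, 1 oxygen; 2 five-membered non-aromatic rings with 1 hetero atom each) in place of a group of 7 heavy atoms (6 carbon, 1 nitrogen; one seven-membered non-aromatic ring with 1 hetero atom), on an aromatic carbon, on an aromatic carbon of a six-membered aromatic ring with 1 nitrogen, part of a fused or bridged system of two rings, next to the ring nitrogen.

The step from compound 1 to compound 2 is the only one that touches this position, and it showed that swapping the ring there moves the number well beyond the scatter. The incoming group brings back smaller rings and a second hydrogen-bond acceptor, so a drop from compound 2 is expected, smaller than that step because a 9.0-fold higher number from compound 1 to compound 2 (0.95 log units; beyond the scatter) involved a hydrogen-bond donor that compound 3 lacks. Compound 3 is therefore expected at 800 nM, within 250 nM to 2500 nM, a step of a 2.3-fold lower number from compound 2 to compound 3 (0.35 log units; beyond the scatter).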

Compound 3, half-maximal effective concentration: 70 nM
Compound 3: the middle estimate sits 11-fold (1.06 log units) above what was measured; measured number below the stated range.
By their numbers in this assay, from the lowest: compound 3; then compound 1; then compound 2.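

Replacing azepan-1-yl with the group of two five-membered rings gives a 26-fold lower number from compound 2 to compound 3 (1.41 log units; beyond the scatter) in this assay, even though both groups have 7 heavy atoms, so heavy-atom count alone does not set the number at this position. The further step, a 2.9-fold lower number from compound 1 to compound 3 (0.46 log units; beyond the scatter), shows that the amino group of 3-aminopyrrolidin-1-yl is not needed for a low number here: the entering group has 0 hydrogen-bond donors, yet compound 3 has the lowest number of the three. No measurement shown explains why this group does so much better than azepan-1-yl.

The entering group differs from azepan-1-yl in two ways at once, carrying an oxygen and having two five-membered rings instead of one seven-membered ring, and these three compounds cannot separate the two changes. A morpholin-4-yl group would offer a ring oxygen without the two-ring shape, while an all-carbon version of the two-ring group, with a methylene in place of the oxygen, would keep the shape without the oxygen.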